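This account rests on a few compounds, and the source may have more. Where it says the series, first, only, none or still open, it means among the compounds named here.

Measured so far in an assay on isolated protein (Oryctolagus cuniculus) with Thromboxane-A synthase (Homo sapiens) as the target, tested at 1 uM; a higher number here means more inhibition at the concentration tested (going by the name of the read-out), a lower number less inhibition:

Compound 1, `C=CCn1nc(-c2cccnc2)c2ccccc2c1=O`, gives 70%.
Compound 2, `CC(=O)OCCn1nc(-c2cccnc2)c2ccccc2c1=O`, gives 32%.
Compound 3, `CCOC(=O)CCCn1nc(-c2cccnc2)c2ccccc2c1=O`, gives 95%.

Compound 3 stands highest of the three; the nearest is compound 1, the furthest compound 2. The three differ only in the group on a saturated chain carbon bound to an aromatic nitrogen, and this group matters: a number 38 percentage points lower from compound 1 to compound 2 (beyond the scatter), a number 25 percentage points higher from compound 1 to compound 3 (beyond the scatter) and a number 63 percentage points higher from compound 2 to compound 3 (beyond the scatter).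

Compound 4, `O=c1c2ccccc2c(-c2cccnc2)nn1CCSc1ncccn1`, is still to be measured in this assay. It differs from compound 3 in one place: (pyrimidin-2-yl)sulfanyl in place of (ethoxycarbonyl)methyl on a saturated chain carbon, two bonds along the chain from an aromatic nitrogen. For the measured compounds named here, the steps that bear on it are the two that change this same position, a number 63 percentage points higher from compound 2 to compound 3 (beyond the scatter) and a number 38 percentage points lower from compound 1 to compound 2 (beyond the scatter), both large. Going by the values given here, no measured compound carries the entering group, so the direction is uncertain; since compound 3 already stands high, a modest fall is expected rather than a further rise, and the estimated step is a number 20 percentage points lower from compound 3 to compound 4 (beyond the scatter). Compound 4 is thus expected to give about 75%, with a range from 40% to 97%.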

Compound 4, a percentage reported as inhibition, at one concentration (the size of the read-out at that concentration, not a potency): 86%
The estimate for compound 4 lay 11 percentage points below the measured number, and the stated range covers the measured number.
By their numbers in this assay, from the lowest: compound 2; then compound 1; then compounds 4 and 3 (each within the scatter of the next).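

Swapping (ethoxycarbonyl)methyl for (pyrimidin-2-yl)sulfanyl leaves this assay within the scatter (a number 9 percentage points lower from compound 3 to compound 4 (within the scatter)), so a high number at this position does not depend on the ester chain: a group with an aromatic ring and a sulfur does as well. The new group also reads well above both acetoxy (a number 54 percentage points higher from compound 2 to compound 4 (beyond the scatter)) and, by a smaller margin, the shorter vinyl (a number 16 percentage points higher from compound 1 to compound 4 (beyond the scatter)). Nothing measured here explains why these different groups give such similar numbers.

The compounds shown cannot separate the part played by the sulfur from that of the pyrimidine ring, and a phenylsulfanyl group or a free carboxylic acid in place of the ethyl ester would test this further. A reading at a single concentration also leaves open whether compound 3 and compound 4 truly match in potency.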